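A Prop-1-en-1-yl Group Replaces the Selenium-Bearing Chain

A few compounds are considered here, and "the series" means these few. Any claim that something is new, unique, unknown or untested is made for them only; others in the source may bear on it.

Compound 1, `COc1ccc(CN(C(=O)CCCl)c2cc(OC)c(OC)c(OC)c2)cc1O`, gives 140 nM in a functional assay on MGC-803 cells (Homo sapiens) for inhibition, read by MTT assay, with a stated time of 48 h; on this read-out lower numbers stand for stronger inhibition and higher numbers for weaker inhibition.
Compound 2, `C/C=C/C(=O)N(Cc1ccc(OC)c(Br)c1)c1cc(OC)c(OC)c(OC)c1`, gives 6430 nM in this assay.
Compound 3, `COc1ccc(CN(C(=O)C[Se]C#N)c2cc(OC)c(OC)c(OC)c2)cc1O`, gives 270 nM in this assay.

Among these three numbers, compound 3 holds the second highest. Compound 1 is nearest to it: a 1.9-fold higher number from compound 1 to compound 3 (0.29 log units; within the scatter). Compound 2 is furthest, with a number beyond the scatter from compound 3.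

Compound 4, `C/C=C/C(=O)N(Cc1ccc(OC)c(O)c1)c1cc(OC)c(OC)c(OC)c1`, has not yet been measured. It differs from compound 3 in one place: a group of 3 heavy atoms (3 carbon; no ring) in place of a group of 4 heavy atoms (2 carbon, 1 nitrogen, 1 selenium; no ring), on a carbonyl carbon.

Among the compounds with values here, only one measured step touches the same carbonyl carbon, the one from compound 1 to compound 3, and it stayed within the scatter: a 1.9-fold higher number from compound 1 to compound 3 (0.29 log units; within the scatter). Within the data shown here, compound 2 carries the same prop-1-en-1-yl group as compound 4, yet it also differs from compound 4 elsewhere, so no single-change step links the two; compound 2 simply gives 6430 nM, the weakest inhibition seen so far. Weighing the quiet step against the high number of compound 2, a moderate rise in the number is expected: a 3.0-fold higher number from compound 3 to compound 4 (0.47 log units; beyond the scatter). Compound 4 is therefore estimated at 800 nM, within a range from 150 nM to 5000 nM.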

Compound 4, half-maximal inhibitory concentration: 27 nM
Compound 4: middle estimate off by 30-fold (1.47 log units), on the high side, outside the stated range (below it).
By their numbers in this assay, from the lowest: compound 4; then compounds 1 and 3 (each within the scatter of the next); then compound 2.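

On the carbonyl carbon, prop-1-en-1-yl makes a clearer difference in this assay than the earlier swap between the 2-chloroethyl and selenium-bearing chains, which stayed within the scatter: replacing those chains gives steps beyond the scatter (a 10-fold lower number from compound 3 to compound 4 (1.00 log units; beyond the scatter); a 5.2-fold lower number from compound 1 to compound 4 (0.71 log units; beyond the scatter)). Yet prop-1-en-1-yl alone does not secure a low number, since with it held fixed, hydroxy in place of bromo on an aromatic carbon gives the largest step so far (a 240-fold lower number from compound 2 to compound 4 (2.38 log units; beyond the scatter)). Compound 4 is therefore the strongest inhibitor of the four, with its steps to all three others beyond the scatter.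

On these data alone, whether an amine on that aromatic carbon, or a longer chain on the carbonyl carbon, would keep the number this low remains open. Nothing measured here explains how either change acts on these cells.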